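Working notes: from compound 3 to compound 4

This account rests on a few compounds, and the source may have more. Where it says the series, first, only, none or still open, it means among the compounds named here.

- compound 1 (`CCCNC(=O)N1CCN(c2ncnc3sc(-c4ccc(N5CCN(C)CC5)cc4)cc23)CC1`), 8330 nM
- compound 2 (`COc1ccc(NC(=O)N2CCN(c3ncnc4sc(-c5ccc(N6CCN(C)CC6)cc5)cc34)CC2)cc1`), 20900 nM
- compound 3 (`CN1CCN(c2ccc(-c3cc4c(N5CCN(C(=O)Nc6ccc(Cl)c(C(F)(F)F)c6)CC5)ncnc4s3)cc2)CC1`), 2220 nM

All three values come from a functional assay on MDA-MB-231 cells (Homo sapiens) for antiproliferative activity, read by MTT assay, with a stated time of 48 h (on this read-out higher numbers stand for weaker inhibition and lower numbers for stronger inhibition), and the compounds differ only in the group on an amide-type nitrogen. Compound 3 has the lowest of the three numbers, with compound 1 nearest and compound 2 furthest.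

Compound 4 (`CN1CCN(c2ccc(-c3cc4c(N5CCN(C(=O)Nc6cc(C(F)(F)F)ccc6F)CC5)ncnc4s3)cc2)CC1`) is not yet measured. It carries 2-fluoro-5-(trifluoromethyl)phenyl in place of 4-chloro-3-(trifluoromethyl)phenyl on an amide-type nitrogen.

Within the data shown here, three measured steps bear on this place, and all are modest. Replacing propyl gives (a 2.5-fold higher number from compound 1 to compound 2 (0.40 log units; beyond the scatter)) with 4-methoxyphenyl and (a 3.8-fold lower number from compound 1 to compound 3 (0.57 log units; beyond the scatter)) with 4-chloro-3-(trifluoromethyl)phenyl. Among the measured compounds shown here, the closest precedent is the exchange of one substituted phenyl for another (a 9.4-fold lower number from compound 2 to compound 3 (0.97 log units; beyond the scatter)), the largest of the three. That exchange removes the methoxy group, whereas the present change keeps a trifluoromethyl group and a halogen. For the measured compounds named here, no measured step exchanges one such phenyl for another, so a smaller step is expected here, with a slight lean towards a higher number.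

The expected outcome is a 1.4-fold higher number from compound 3 to compound 4 (0.13 log units; within the scatter) in this assay and no clear separation. In this assay the expected value for compound 4 is 3000 nM with an estimated range of 1100 nM to 8500 nM for the measurement.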

Compound 4, half-maximal inhibitory concentration: 9090 nM
Beside the measured number, compound 4's estimate is 3.0-fold (0.48 log units) below it, and the stated range ends below it.
By their numbers in this assay, from the lowest: compound 3; then compounds 1 and 4 (each within the scatter of the next); then compound 2.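

In this assay, the exchange on the amide-type nitrogen gives a 4.1-fold higher number from compound 3 to compound 4 (0.61 log units; beyond the scatter), so two phenyl groups of 11 heavy atoms, each carrying a trifluoromethyl group and one halogen, are not interchangeable at this place. Sharing those features does not carry over the low number of compound 3, and an aromatic group alone does not set the level either: the step from 4-methoxyphenyl is a 2.3-fold lower number from compound 2 to compound 4 (0.36 log units; beyond the scatter), while the step from propyl is a 1.1-fold higher number from compound 1 to compound 4 (0.04 log units; within the scatter), leaving no separation from the propyl urea. No evidence at hand accounts for the difference between the two substituted phenyl groups.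

As far as these compounds go, it remains open whether the gap follows the identity of the halogen or the arrangement of the substituents; 2-chloro-5-(trifluoromethyl)phenyl would keep the arrangement of compound 4 with the halogen of compound 3. From the compounds shown here alone, it is equally open whether a longer alkyl chain or a benzyl group on this nitrogen would give numbers close to those of compound 1 or compound 3.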